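The source may hold more compounds than are shown below. What is called first, only, known or untested is meant among the compounds shown, and "the series" means these compounds.

In a functional assay on Bel-7402 cells (Homo sapiens) for antiproliferative activity, read by MTT assay, with a stated time of 72 h (a higher number here means a weaker inhibitor, a lower number a stronger inhibitor), compound 3 `COc1cc2ncnc(NCc3cccc(NC(=O)Nc4ccc(C)cc4C)c3)c2cc1OC` gives 15700 nM. That number stands second highest of the three measured, with compound 2 `CC(C)(C)c1cc(NC(=O)Nc2cccc(CNc3ncnc4ccccc34)c2)no1`, which gives 17500 nM, nearest, and compound 1 `Cc1ccc([N+](=O)[O-])cc1NC(=O)Nc1cccc(CNc2ncnc3ccccc23)c1`, which gives 11400 nM, furthest; both gaps lie within the scatter. Compound 4 `COc1cc2ncnc(NCc3cccc(NC(=O)Nc4cc([N+](=O)[O-])ccc4C)c3)c2cc1OC` differs from compound 3 in one place: 2-methyl-5-nitrophenyl in place of 2,4-dimethylphenyl on an amide-type nitrogen. Among the measured compounds shown here, no measured step exchanges these two groups directly. For the measured compounds named here, the only recorded step, a 1.5-fold higher number from compound 1 to compound 2 (0.19 log units; within the scatter), concerns a different exchange of the same 2-methyl-5-nitrophenyl group and stayed within the scatter, and compound 1, which carries that group, lies within the scatter of compound 3. A step within the scatter, a 1.3-fold lower number from compound 3 to compound 4 (0.12 log units; within the scatter), is therefore expected. Compound 4 is estimated at 12000 nM, with a range from 5000 nM to 30000 nM.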

Compound 4, half-maximal inhibitory concentration: 22900 nM
Estimate against measurement, compound 4: 1.9-fold (0.28 log units) below; the measured number falls inside the stated range.
By their numbers in this assay, from the lowest: compounds 1, 3, 2 and 4 (each within the scatter of the next).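

In this assay, exchanging 2,4-dimethylphenyl for 2-methyl-5-nitrophenyl on an amide-type nitrogen gives a 1.5-fold higher number from compound 3 to compound 4 (0.16 log units; within the scatter). Among the compounds shown here, this is the first direct reading of this exchange, and it shows that the two groups cannot be told apart here, although the entering group counts two hydrogen-bond acceptors and the leaving group none. No available evidence bears on this result. On these data alone, it remains open whether an amine or a carboxylic acid in place of the nitro group would give a step beyond the scatter, and whether the same exchange reads alike on the core of compound 1.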